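The source may hold more compounds than are shown below. What is called first, only, known or untested is meant among the compounds shown, and "the series" means these compounds.

Measured so far:
Compound 1 `C=CCc1ccc(OCc2cn(-c3cccc([N+](=O)[O-])c3)nn2)c(O)c1`: 42.3%
Compound 2 `C=CCc1ccc(OCc2cn(-c3cc(OC)c(OC)c(OC)c3)nn2)c(O)c1`: 37.3%
Compound 3 `C=CCc1ccc(OCc2cn(-c3ccc(OC)cc3)nn2)c(O)c1`: 38.8%

All three values come from a functional assay on MCF7 cells (Homo sapiens) for inhibition, read by MTT assay, with a stated time of 72 h, tested at 30 uM; on this read-out higher numbers stand for more inhibition of growth at the one concentration tested and lower numbers for less inhibition of growth. Compound 1 stands within the scatter of both compound 3 and compound 2, so the numbers do not separate it from either.

Compound 4 `C=CCc1ccc(OCc2cn(-c3cccc(C#N)c3)nn2)c(O)c1` has cyano in place of nitro on an aromatic carbon, meta to a large group: cyano in place of nitro on an aromatic carbon.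

Among the measured compounds shown here, no measured pair differs in one place, so no direct step is available. With compound 2 at 37.3% and compound 3 at 38.8%, none of the three substituent patterns stands apart, and no step beyond the scatter is expected in this assay. The expected change is a number 2.3 percentage points lower from compound 1 to compound 4 (within the scatter). For compound 4 the estimate is 40%, with an expected range of 30% to 50%.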

Compound 4, percent growth inhibition at one concentration: 31.9%
Estimate against measurement, compound 4: 8.1 percentage points above; the measured number falls inside the stated range.
By their numbers in this assay, from the lowest: compounds 4, 2, 3 and 1 (each within the scatter of the next, the first and the last beyond it).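

In this assay, among the compounds shown here, the change of nitro to cyano on this aromatic carbon gives a number 10.4 percentage points lower from compound 1 to compound 4 (beyond the scatter) as the first step that can be read directly, so this position does respond to a small change of group. The change of 4-methoxyphenyl to 3-cyanophenyl on the aromatic nitrogen gives a number 6.9 percentage points lower from compound 3 to compound 4 (within the scatter) and does not separate those two compounds. Nothing available bears on the reason for the nitro to cyano step.

Open, on these data alone, is whether an amine or a carboxylic acid on this aromatic carbon would stand with compound 1 or with compound 4. Also open, as far as these compounds go, is whether the nitro to cyano step holds at concentrations other than the single one tested.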